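The source may hold more compounds than are shown below. What is called first, only, known or untested is meant among the compounds shown, and "the series" means these compounds.

The measured compounds:

compound 1, `CCN1CCN(c2cc(C)c3cc(NC(=O)c4cccc(Cl)c4)ccc3n2)CC1`, 3820 nM
compound 2, `CCN(CC)CCNc1cc(C)c2cc(NC(=O)c3ccc(Cl)c(Cl)c3)ccc2n1`, 1420 nM
compound 3, `CCN1CCN(c2cc(C)c3cc(NC(=O)c4ccco4)ccc3n2)CC1`, 41200 nM

In a functional assay on MCF7 cells (Homo sapiens) for antiproliferative activity, read by MTT assay, with a stated time of 72 h (on this read-out higher numbers stand for weaker inhibition and lower numbers for stronger inhibition), compound 1 stands second highest of the three numbers shown; compound 2 sits at a lower number, and compound 3 at a far higher one. For the measured compounds named here, the one step that joins compound 1 to another measured compound is an 11-fold higher number from compound 1 to compound 3 (1.03 log units; beyond the scatter), and it concerns the whole aryl group on the carbonyl, not a single substituent on it. Compound 4, `CCN1CCN(c2cc(C)c3cc(NC(=O)c4cccc(C)c4)ccc3n2)CC1`, differs from compound 1 in one place: methyl in place of chloro on an aromatic carbon. Going by the values given here, no measured pair shows a chloro replaced by a methyl, so the step from compound 1 to compound 4 has no direct precedent; the shift from 3-chlorophenyl to 3-methylphenyl keeps the ring on the carbonyl intact, and the large loss seen in compound 3 is not expected to repeat. The number for compound 4 is therefore expected to lie close to that of compound 1, with a 1.3-fold higher number from compound 1 to compound 4 (0.12 log units; within the scatter) likely within the scatter or only a little beyond it toward a higher number. The estimate for compound 4 in this assay is 5000 nM, between 2000 nM and 12000 nM.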

Compound 4, half-maximal inhibitory concentration: 7800 nM
Beside the measured number, compound 4's estimate is 1.6-fold (0.19 log units) below it, and the stated range covers the measured number.
By their numbers in this assay, from the lowest: compound 2; then compound 1; then compound 4; then compound 3.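

In this assay, exchanging chloro for methyl on this aromatic carbon gives a 2.0-fold higher number from compound 1 to compound 4 (0.31 log units; beyond the scatter), so this place on the ring responds to a change of one heavy atom, though the step is modest. With the methyl in place, the aromatic group on the carbonyl still matters: a 5.3-fold lower number from compound 3 to compound 4 (0.72 log units; beyond the scatter), and this step is smaller than an 11-fold higher number from compound 1 to compound 3 (1.03 log units; beyond the scatter), so 3-methylphenyl recovers only part of the difference between furan-2-yl and 3-chlorophenyl. Nothing measured here bears on the reason for either step.

The compounds shown leave open how a methoxy, a trifluoromethyl or an amine would read on this same aromatic carbon. They also leave open whether the exchange of chloro for methyl gives a similar step when the side chain of compound 2 is present.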